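Replacing fluoro with isobutylcarbamoyl on an inactive scaffold

This account rests on a few compounds, and the source may have more. Where it says the series, first, only, none or still open, it means among the compounds named here.

Compound 1 `CC[C@@H]1C(=O)N(C)c2cnc(-n3ccc4cc(F)ccc43)nc2N1C1CCCC1`: "not active" (no number reported)
Compound 2 `CC[C@@H]1C(=O)N(C)c2cnc(Nc3ccc(S(N)(=O)=O)cc3)nc2N1C1CCCC1`: 394 nM
Compound 3 `CCC1C(=O)N(C)c2cnc(Nc3ccc(S(=O)(=O)NCCCO)cc3)nc2N1c1ccn(C)n1`: 21600 nM

Three compounds sharing a common core were examined in a functional assay on MCF7 cells (Homo sapiens) for antiproliferative activity, read by CCK-8 assay, with a stated time of 72 h; a lower number here means a stronger inhibitor of growth, a higher number a weaker inhibitor of growth. Compound 1 `CC[C@@H]1C(=O)N(C)c2cnc(-n3ccc4cc(F)ccc43)nc2N1C1CCCC1` was reported as "not active" (no number reported), so no single number places it on the scale. Compound 2 `CC[C@@H]1C(=O)N(C)c2cnc(Nc3ccc(S(N)(=O)=O)cc3)nc2N1C1CCCC1` gave 394 nM in this assay, while compound 3 `CCC1C(=O)N(C)c2cnc(Nc3ccc(S(=O)(=O)NCCCO)cc3)nc2N1c1ccn(C)n1` gave 21600 nM; the two differ in more than one place, so their values are simply taken as they stand.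

Compound 4 `CC[C@@H]1C(=O)N(C)c2cnc(-n3ccc4cc(C(=O)NCC(C)C)ccc43)nc2N1C1CCCC1` differs from compound 1 by a single change: isobutylcarbamoyl in place of fluoro on an aromatic carbon. Within the data shown here, no measured pair shows this kind of exchange, so the size of the step in this assay cannot be read from the data. Since compound 1 is recorded as "not active" (no number reported), there is no baseline from which to count a direction. Compound 4 is expected to remain weak in this assay, with an estimated value of 15000 nM and a range from 3000 nM to 60000 nM.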

Compound 4, concentration for 50% growth inhibition: 953 nM
Compound 4: middle estimate off by 16-fold (1.20 log units), on the high side, and the stated range ends above it.
By their numbers in this assay, from the lowest: compound 2; then compound 4; then compound 3.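

Among these compounds, compound 4 gives 953 nM in this assay but compound 1 has no number, so no step between compound 1 and compound 4 can be read. How much isobutylcarbamoyl in place of fluoro changes growth inhibition stays open, and no measurement shown offers an explanation.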